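Adding Two Carbons to the Ether Chain of Compound 2

The compounds below may be only part of what the source reports. "The series", "measured", "known", "first", "only" and "open" are said of these compounds alone.

Measured so far in a physicochemical assay for solubility, tested at 272 nM; on this read-out higher numbers stand for higher solubility and lower numbers for lower solubility:
- compound 1 `CCCCCCCCCCCCCCCCOCC(COP(=O)(O)OP(=O)(O)OC[C@H]1OC(n2ccc(N)nc2=O)[C@@H](O)[C@@H]1O)OC(=O)CCCCCCCCCCCCCCC`: 130000 nM
- compound 2 `CCCCCCCCCCCCCC(=O)OC(COCCCCCCCCCCCC)COP(=O)(O)OP(=O)(O)OC[C@H]1OC(n2ccc(N)nc2=O)[C@@H](O)[C@@H]1O`: > 146000000 nM
- compound 3 `CCCCCCCCCCCCCCCC(=O)OC(COCCCCCCCCCCCC)COP(=O)(O)OP(=O)(O)OC[C@H]1OC(n2ccc(N)nc2=O)[C@@H](O)[C@@H]1O`: > 131000000 nM.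

For compound 2 the value > 146000000 nM is a limit of this assay, not a number. For compound 3 the value > 131000000 nM is likewise a limit. Compound 1 alone gives a number, at 130000 nM.

Compound 4 `CCCCCCCCCCCCCCOCC(COP(=O)(O)OP(=O)(O)OC[C@H]1OC(n2ccc(N)nc2=O)[C@@H](O)[C@@H]1O)OC(=O)CCCCCCCCCCCCC` differs from compound 2 by ethyl in place of hydrogen on a saturated chain carbon, ten or more bonds along the chain from an oxygen on a saturated carbon. Among the measured compounds shown here, two measured steps bear on this. The closest is an at least 1000-fold higher number from compound 1 to compound 3 (3.00 log units; beyond the scatter), which runs in the opposite direction at the same place and is at least large, set by the limit of > 131000000 nM in this assay, at which 1 of the 3 values shown sits. The other is a step that the two limits leave unreadable from compound 2 to compound 3, where the limit of > 146000000 nM in this assay, at which 1 of the 3 values shown sits, and the limit of > 131000000 nM in this assay, at which 1 of the 3 values shown sits, leave the size unreadable. Adding ethyl where compound 1 carries butyl is therefore expected to lower solubility, but compound 4 sits between compound 2 and compound 1 in chain length, so the drop is expected to be smaller than the whole step from compound 1 to compound 3. Compound 4 is expected at 20000000 nM, within 1000000 nM to 146000000 nM, an estimated step of an at least 7.3-fold lower number from compound 2 to compound 4 (0.86 log units; beyond the scatter).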

Compound 4, solubility: > 121000000 nM
Compound 4: only a limit was reported; the forecaster's own chance of this, stated with the estimate: 40%; at least 6.0-fold (0.78 log units) between middle value and limit.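

Compound 2 and compound 4 each give only a limit in this assay and no number, so the step between them cannot be read. The compounds shown leave open whether ethyl in place of hydrogen here changes the result in this assay at all, and by how much.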